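A few compounds are considered here, and "the series" means these few. Any claim that something is new, unique, unknown or untested is made for them only; others in the source may bear on it.

Series notes. Compound 1 `Nc1nc2c(c(-c3ccco3)cn2[C@@H]2O[C@H](CO)[C@@H](O)[C@H]2O)c(=O)[nH]1` and compound 2 `Nc1nc2c(c(-c3cc4ccccc4o3)cn2[C@@H]2O[C@H](CO)[C@@H](O)[C@H]2O)c(=O)[nH]1` share one core; compound 3 `CNc1ncnc2c1c(-c1cc3ccccc3o1)cn2[C@@H]1O[C@H](CO)[C@@H](O)[C@H]1O` carries another core, and the difference between the two cores is not broken down here. Compound 4 `CNc1ncnc2c1c(-c1ccco1)cn2[C@@H]1O[C@H](CO)[C@@H](O)[C@H]1O` has not yet been measured. In a functional assay on HCT-116 cells (Homo sapiens), read by MTT assay, with a stated time of 72 h (on this read-out lower numbers stand for stronger inhibition and higher numbers for weaker inhibition), compound 2 reaches only a limit, > 100000 nM. Compound 1 likewise sits at a limit in this assay, > 20000 nM. Compound 3 also gives a limit in this assay, > 20000 nM. The change furan-2-yl in place of 1-benzofuran-2-yl on an aromatic carbon yields a step that the two limits leave unreadable from compound 2 to compound 1. The same change, (furan-2-yl in place of 1-benzofuran-2-yl on an aromatic carbon), leads from compound 3 to compound 4. With the limit of > 100000 nM in this assay, at which 1 of the 3 values shown sits, and the limit of > 20000 nM in this assay, at which 2 of the 3 values shown sit, no step size can be read from the measured pair. For compound 4 the expected step that the limit leaves unreadable from compound 3 to compound 4 is likewise not readable. Compound 4 is estimated at 40000 nM, most probably reported again as a limit.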

Compound 4, half-maximal inhibitory concentration: 230 nM
Beside the measured number, compound 4's estimate is 170-fold (2.24 log units) above it, and the stated range ends above it.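

In this assay, furan-2-yl in place of 1-benzofuran-2-yl on an aromatic carbon gives an at least 86-fold lower number from compound 3 to compound 4 (1.93 log units; beyond the scatter) on that core. On the core of compound 1 the same change leaves no readable step: compound 1 and compound 2 both stand at limits, so the data neither confirm nor exclude that the drop carries over from one core to the other. The step rests on a single pair, and nothing given here accounts for its size.

The compounds shown leave open how other groups on this aromatic carbon, such as an amine or a carboxylic acid, would read on either core. Also open, on these data alone, is whether any group brings the core of compound 1 to a value that is not a limit.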